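Adding a Second Fluorine: What to Expect for Compound 4

The compounds below may be only part of what the source reports. "The series", "measured", "known", "first", "only" and "open" are said of these compounds alone.

Of the compounds shown here, three have been measured in a functional assay on MCF-10A cells (Homo sapiens) for antiproliferative activity, with a stated time of 48 h; a higher number here means that more compound is needed for the effect, a lower number that less compound is needed. Compound 2 `COc1ccc2nc(C)cc(SCc3ccccc3)c2c1` gives 30600 nM. Compound 1 `COc1ccc2nc(C)cc(SCc3ccc(F)cc3)c2c1` gives 41000 nM. The difference between these two is fluoro in place of hydrogen on an aromatic carbon, and it produced a 1.3-fold higher number from compound 2 to compound 1 (0.13 log units; within the scatter). Compound 3 `COc1ccc2nc(C)cc(NCc3cccc(F)c3)c2c1` carries a different core; how its core differs from that of compound 2 is not broken down here. In this assay compound 3 gives 11300 nM, the lowest of the three numbers and beyond the scatter from both others.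

Compound 4 `COc1ccc2nc(C)cc(NCc3cc(F)cc(F)c3)c2c1` has not yet been measured. It differs from compound 3 by fluoro in place of hydrogen on an aromatic carbon. This is the same kind of change as from compound 2 to compound 1, but not the same: there the fluorine entered para to a large group, here it enters meta to a fluoro group and meta to a large group. Because the earlier step was a 1.3-fold higher number from compound 2 to compound 1 (0.13 log units; within the scatter), only a small step is expected for compound 4, estimated as a 1.2-fold higher number from compound 3 to compound 4 (0.06 log units; within the scatter). Compound 4 is expected to give 13000 nM, between 6000 nM and 30000 nM.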

Compound 4, half-maximal effective concentration: 13300 nM
Compound 4: the middle estimate sits 1.0-fold (0.01 log units) below what was measured; measured number inside the range.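

In this assay, fluoro in place of hydrogen on an aromatic carbon gives a 1.2-fold higher number from compound 3 to compound 4 (0.07 log units; within the scatter). Set beside the same kind of change on the other core, the result carries over, as a step that stays inside the usual scatter on both cores: the same change on two cores in this assay, a 1.3-fold higher number (0.13 log units; within the scatter) from compound 2 to compound 1 and a 1.2-fold higher number (0.07 log units; within the scatter) from compound 3 to compound 4, 1.1-fold (0.06 log units) apart, within the scatter of two such steps. This shows only that, on these two cores, adding one fluoro did not move the number by more than repeated measurements normally would; it does not show that the fluoro has a real effect of its own, that the same would hold on a third core, or why the steps look as they do, and the fluorine also enters a different place on each core.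

Going by these compounds, whether a chloro, a methoxy or a carboxylic acid in place of the fluoro would give a step beyond the scatter stays open. So does the outcome of a longer chain linking the core to the fluorinated ring.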